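Cyclopropyl for Methyl on the Ring Nitrogen

The source may hold more compounds than are shown below. What is called first, only, known or untested is meant among the compounds shown, and "the series" means these compounds.

Measured in an assay on HEK293 cells for inhibition of Voltage-dependent T-type calcium channel subunit alpha-1H (Homo sapiens), read by patch clamp, using a membrane potential dye; a higher number here means a weaker inhibitor, a lower number a stronger inhibitor:
compound 1, `CC[C@H](C)[C@H](NC(=O)N1CCC2(CC1)CN(C)C2c1ccc(Cl)cc1)C(=O)OC`: 410 nM
compound 2, `CN1CC2(CCN(C(=O)Nc3cc(F)cc(F)c3)CC2)C1c1ccc(Cl)cc1`: 214 nM
compound 3, `CC[C@H](C)[C@H](NC(=O)N1CCC2(CC1)CN(C(C)C)C2c1ccc(F)cc1)C(=O)OC`: 256 nM

Compound 1 gives the largest of the three numbers, yet its gaps to compound 3 and to compound 2 both lie within the usual scatter, so the three compounds cannot be ranked against one another.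

Compound 4, `CC[C@H](C)[C@H](NC(=O)N1CCC2(CC1)CN(C1CC1)C2c1ccc(Cl)cc1)C(=O)OC`, has not been measured. It differs from compound 1 in one place: cyclopropyl in place of methyl on an amine nitrogen in a ring.

Among the compounds with values here, no measured pair changes only this group. Within the data shown here, the one measured step, a 1.9-fold lower number from compound 1 to compound 2 (0.28 log units; within the scatter), alters the other end of the molecule and stays within the scatter. Compound 3 carries an isopropyl group on the same ring nitrogen together with a 4-fluorophenyl group, so two things differ from compound 1 at once; its value and that of compound 1 are within the scatter of each other. Nothing here shows that a larger group on this nitrogen moves the number beyond the scatter.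

Compound 4 is therefore expected to stay close to compound 1, with an estimated step of a 1.3-fold lower number from compound 1 to compound 4 (0.11 log units; within the scatter) in this assay. The estimate for compound 4 is 320 nM, ranging from 120 nM to 850 nM.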

Compound 4, half-maximal inhibitory concentration: 325 nM
The estimate for compound 4 lay 1.0-fold (0.01 log units) below the measured number; measured number inside the range.
By their numbers in this assay, from the lowest: compounds 2, 3, 4 and 1 (each within the scatter of the next).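

The change of methyl to cyclopropyl on the amine nitrogen in the four-membered ring can now be read on its own: in this assay it gives a 1.3-fold lower number from compound 1 to compound 4 (0.10 log units; within the scatter) with nothing else in the molecule altered. Compound 3 could not show this, as its isopropyl group on the same nitrogen comes together with a 4-fluorophenyl group, whereas this single-change pair shows that a small carbon ring can stand on this nitrogen, close to the ring atom bearing the 4-chlorophenyl group, without a shift that can be told from the scatter. No measurement here bears on why the number holds, so the step stands as a plain observation and no more.

Still open, going by these compounds, is how far this tolerance reaches: a bare hydrogen on this nitrogen, a longer chain such as n-butyl, or a chain ending in a carboxylic acid or an amine could each behave differently from methyl and cyclopropyl. Also open, on these data alone, is whether cyclopropyl on this nitrogen would sit equally quietly with the 3,5-difluorophenyl group of compound 2 at the other end of the molecule.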